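This account rests on a few compounds, and the source may have more. Where it says the series, first, only, none or still open, it means among the compounds named here.

Two compounds of a shared core have been examined in an ADME assay on HUVEC cells (Homo sapiens) for cytotoxicity, read by MTT assay, with a stated time of 48 h; a lower number here means a stronger inhibitor, a higher number a weaker inhibitor. Compound 1 `Nc1nc(-c2ccc(Br)cc2)cn1/N=C/c1cc2ccccc2nc1Cl` gives 11900 nM, the lowest of the two numbers in hand. For the measured compounds named here, compound 2 `Cc1ccc2nc(Cl)c(/C=N/n3cc(-c4ccc(Cl)cc4)nc3N)cc2c1` gives 38500 nM, a number beyond the scatter above that of compound 1; the two differ in more than one place, so no single step separates them. The next compound, compound 3 `Cc1ccc2nc(Cl)c(/C=N/n3cc(-c4ccc(Br)cc4)nc3N)cc2c1`, differs from compound 1 in one place: methyl in place of hydrogen on an aromatic carbon. Going by the values given here, no measured pair shows this change on its own. Compound 2 also carries a methyl on the core and sits well above compound 1, which hints, though weakly, that the number for compound 3 will move upward, toward a weaker inhibitor. The step expected a 1.7-fold higher number from compound 1 to compound 3 (0.23 log units; within the scatter) is a modest one, likely at the edge of the scatter. Compound 3 is therefore expected to give 20000 nM, within 9000 nM to 45000 nM.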

Compound 3, half-maximal inhibitory concentration: 13400 nM
The estimate for compound 3 lay 1.5-fold (0.17 log units) above the measured number, within the range that was stated.
By their numbers in this assay, from the lowest: compounds 1 and 3 (each within the scatter of the next); then compound 2.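

In this assay, methyl in place of hydrogen on an aromatic carbon, at the place meta to a fused ring and para to a fused ring, gives a step within the scatter (a 1.1-fold higher number from compound 1 to compound 3 (0.05 log units; within the scatter)). The step that goes beyond the scatter among these compounds is bromo in place of chloro on an aromatic carbon (a 2.9-fold lower number from compound 2 to compound 3 (0.46 log units; beyond the scatter)), so the higher number of compound 2 can no longer be read as a sign that the methyl raises the number, as the two earlier compounds differed in both places. No measurement offered here explains either step. Going by these compounds, it remains open whether the bromo for chloro step would be of similar size on the core of compound 1, which has no methyl. Also open, on these data alone, is whether an amine, a carboxylic acid or a longer chain on that same aromatic carbon would stay within the scatter of compound 1.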